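Trimming an Unsaturated Tail: From Compound 2 to Compound 4

This account rests on a few compounds, and the source may have more. Where it says the series, first, only, none or still open, it means among the compounds named here.

Three related compounds have been tested in a functional assay on MDA-MB-231 cells (Homo sapiens) for antiproliferative activity, read by MTT assay; a higher number here means a weaker inhibitor, a lower number a stronger inhibitor. Compound 1 `CCCCC/C=C\C/C=C\CCCCCCCC1(O)CC(=O)c2c(O)cc(O)cc2O1` gives 6790 nM. Compound 2 `CC/C=C\C/C=C\C/C=C\CCCCCCCc1cc(=O)c2c(O)c(C)c(O)c(C)c2o1` gives 6790 nM in this assay, and compound 3 `CCCCC/C=C\C/C=C\CCCCCCCc1cc(=O)c2c(O)cc(O)cc2o1` gives 6790 nM. Compound 2 stands level with compounds 1 and 3: the three values are the same at the digits given, so none of them can be called stronger or weaker than another. All three carry a long hydrocarbon chain on the core, and they differ in the core and in the chain; those differences leave the read-out unmoved here.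

Compound 4 `CCCCCCCCCCCCCCCc1cc(=O)c2c(O)c(C)c(O)c(C)c2o1` has not yet been measured. It keeps the core of compound 2 and alters the chain: a group of 8 heavy atoms (8 carbon; no ring) in place of a group of 10 heavy atoms (10 carbon; no ring), on a saturated chain carbon, seven bonds along the chain from an aromatic carbon. Within the data shown here, no measured pair in this set differs in one place only, so there is no measured step to lean on. What the three measured values do show is that changes in chain and core left the number where it was. On that basis the expected step is a 1.0-fold higher number from compound 2 to compound 4 (0.00 log units; within the scatter), small, in no set direction and within the scatter. Compound 4 is therefore expected to give about 6800 nM in this assay, within a range of 3000 nM to 15000 nM.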

Compound 4, half-maximal inhibitory concentration: > 87000 nM
Compound 4: only a limit was reported (the forecaster's own chance of this, stated with the estimate: 10%); at least 12-fold (1.10 log units) between middle value and limit.
By their numbers in this assay, from the lowest: compounds 1, 2 and 3 (each within the scatter of the next). At a limit, above all of these: compound 4.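

Among these compounds, this is the first change in the set made in one place only, and it moves the read-out well beyond the scatter: this assay shows an at least 12-fold higher number from compound 2 to compound 4 (1.10 log units; beyond the scatter). For compound 4 the reported value is a limit and not a number: the limit of > 87000 nM in this assay, at which 1 of the 4 values shown sits. The equal values of compounds 1, 2 and 3 gave no sign of it, since those compounds differ in more than one place, but with the core of compound 2 held fixed, this part of the chain, on a saturated chain carbon, seven bonds along the chain from an aromatic carbon, clearly matters for activity in this assay.

The swap of the group of compound 2 with 3 double bonds for octyl shortens the chain and removes all the double bonds at once, so the two changes cannot be told apart from this pair, and a saturated decyl group or a group of that same length with a single double bond would be needed to separate them. From the compounds shown here alone, how a longer chain, or a chain carrying a carboxylic acid or an amine at this place, would behave also remains open.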